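A few compounds are considered here, and "the series" means these few. Any claim that something is new, unique, unknown or untested is made for them only; others in the source may bear on it.

In a functional assay for inhibition, using microsomes, tested at 100 ug/mL (on this read-out lower numbers stand for a stronger effect and higher numbers for a weaker effect at the one concentration tested), compound 1, with the structure `CCOC(=O)C1=C(C)N(c2ccccc2)C=CC1c1ccccc1`, gives -19.9%. Compound 2, with the structure `CCOC(=O)C1=C(C)N(c2ccc(Cl)cc2)C=CC1c1ccccc1`, differs from compound 1 in one place: chloro in place of hydrogen on an aromatic carbon. That change made a step of a number 5.6 percentage points lower from compound 1 to compound 2 (within the scatter). In this assay compound 2 gives -25.5%. Compound 3, with the structure `COC(=O)C1=C(C)N(c2ccccc2)C=C(C)C1c1ccccc1`, is built on a different core; how its core differs from the core of compound 1 is not broken down here. In this assay compound 3 gives -22.7%, a number within the scatter of both compound 1 and compound 2, so no order among the three can be read from it.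

Compound 4, with the structure `COC(=O)C1=C(C)N(c2cccc(Cl)c2)C=C(C)C1c1ccccc1`, has not yet been measured. It differs from compound 3 in one place: chloro in place of hydrogen on an aromatic carbon. For the measured compounds named here, this is the same kind of change as the one from compound 1 to compound 2, but not the same: there the chloro enters para to a large group, here it enters meta to a large group. A step of about a number 4.3 percentage points lower from compound 3 to compound 4 (within the scatter) is expected because the earlier change gave a number 5.6 percentage points lower from compound 1 to compound 2 (within the scatter). Compound 4 is therefore estimated to give -27% in this assay, with a likely range from -40% to -14%.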

Compound 4, a percentage reported as activity, at one concentration (the size of the read-out at that concentration, not a potency): -16.2%
Estimate against measurement, compound 4: 10.8 percentage points below; the range from low to high includes it.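

In this assay, the change from phenyl to 3-chlorophenyl gave a step of a number 6.5 percentage points higher from compound 3 to compound 4 (within the scatter). Set beside the earlier chloro step, the new step does not separate from it: the same change on two cores in this assay, a number 5.6 percentage points lower (within the scatter) from compound 1 to compound 2 and a number 6.5 percentage points higher (within the scatter) from compound 3 to compound 4, 12.1 percentage points apart, within the scatter of two such steps. This gives no sign that the core alters what a chloro does in this series, but it does not show that the change carries over either, since neither step can be told from the usual scatter and the chloro sits at a different place on the ring in compound 2 and compound 4.

The compounds shown carry only hydrogen or chloro on this aromatic ring, so it remains open whether a different group there, such as a methoxy group, an amine or a carboxylic acid, would give a step beyond the scatter on either core. Also open, from the compounds shown here alone, is how chloro would compare on the two cores if it stood at the same place on the ring in both.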